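The source may report more compounds than this note shows. Statements on the series, on what has been measured and on what is new or still open speak of the compounds shown alone.

Measured so far:

Compound 1, `C=C1CC[C@@H]2[C@](C)(CO)[C@H](O)CC[C@@]2(C)[C@@H]1C/C=C1/C(=O)OC[C@H]1OC(=O)CSc1cccs1`: in a functional assay on PC-3 cells (Homo sapiens) for inhibition, read by MTT assay, with a stated time of 48 h (on this read-out higher numbers stand for weaker inhibition and lower numbers for stronger inhibition), compound 1 gives 18000 nM.

Compound 2, `C=C1CC[C@@H]2[C@](C)(CO)[C@H](O)CC[C@@]2(C)[C@@H]1C/C=C1/C(=O)OC[C@H]1OC(=O)CCCSc1cccs1`: in this assay compound 2 gives 16000 nM.

Among the measured compounds shown here, of these two numbers the one for compound 2 is the smaller, yet the step of a 1.1-fold lower number from compound 1 to compound 2 (0.05 log units; within the scatter) lies within the scatter of repeated measurements, so the two compounds cannot be told apart on potency. That step concerns only the length of the chain between the ester carbonyl and the sulfur; the aromatic ring on the sulfur was the same in both.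

Compound 3, `C=C1CC[C@@H]2[C@](C)(CO)[C@H](O)CC[C@@]2(C)[C@@H]1C/C=C1/C(=O)OC[C@H]1OC(=O)CCCSc1ccccn1`, has not been measured in this assay. It differs from compound 2 in one place: pyridin-2-yl in place of thiophen-2-yl on a sulfur. For the measured compounds named here, no measured step tests an exchange of this ring, so the only guide is the small effect of the one change seen nearby. The step from compound 2 to compound 3 is therefore expected to stay within the scatter, and the estimated step is no change at the digits printed from compound 2 to compound 3 (within the scatter). Compound 3 is thus expected to give about 16000 nM, with a likely range from 6000 nM to 45000 nM.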

Compound 3, half-maximal inhibitory concentration: 14000 nM
Compound 3: middle estimate off by 1.1-fold (0.06 log units), on the high side; measured number inside the range.
By their numbers in this assay, from the lowest: compounds 3, 2 and 1 (each within the scatter of the next).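

In this assay the ring on the sulfur is put to the test here, and the exchange of thiophen-2-yl for pyridin-2-yl gives a 1.1-fold lower number from compound 2 to compound 3 (0.06 log units; within the scatter) for a five-membered and a six-membered aromatic ring, so at this place the two rings cannot be told apart. Changing the chain and the ring together, with 2-((pyridin-2-yl)sulfanyl)ethyl in place of (thiophen-2-yl)sulfanyl, gives a 1.3-fold lower number from compound 1 to compound 3 (0.11 log units; within the scatter) and so separates the compounds no better than either change alone. No measurement available here offers a reason for this lack of difference.

All three compounds carry an aromatic ring with one hetero atom on the sulfur, which leaves open whether a plain phenyl ring, a small alkyl group, an amine or a carboxylic acid at this place would move the number beyond the scatter. On these data alone, it also remains open whether a longer chain between the carbonyl and the sulfur would matter, since the chains compared so far cover only a short range.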